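This account rests on a few compounds, and the source may have more. Where it says the series, first, only, none or still open, it means among the compounds named here.

Working notes on the series in an ADME assay on Vero cells (Chlorocebus sabaeus) for cytotoxicity, read by MTT assay, with a stated time of 48 h (a higher number here means a weaker inhibitor, a lower number a stronger inhibitor), follow. Compound 1 `O=c1cc(N2CCN(CC3CCC(OS(=O)(=O)c4cccnc4)CC3)CC2)sc2c([N+](=O)[O-])cc(C(F)(F)F)cc12` gives > 64 ug/mL as a limit of the assay and not a number. Compound 2 `CCCC(=O)OC1CCC(CN2CCN(c3cc(=O)c4cc(C(F)(F)F)cc([N+](=O)[O-])c4s3)CC2)CC1` gives > 64 ug/mL as a limit too. Compound 3 `O=C(OC1CCC(CN2CCN(c3cc(=O)c4cc(C(F)(F)F)cc([N+](=O)[O-])c4s3)CC2)CC1)C1CCC1` gives > 64 ug/mL as a limit as well. Going by the values given here, the series so far stands at the limit of > 64 ug/mL in this assay, at which 3 of the 3 values shown sit, and nowhere else. Compound 4 `O=C(NC1CCC(CN2CCN(c3cc(=O)c4cc(C(F)(F)F)cc([N+](=O)[O-])c4s3)CC2)CC1)c1ccccc1` has benzamido in place of (cyclobutylcarbonyl)oxy on a saturated ring carbon as its change from compound 3. The measured steps bearing on this are a step that the two limits leave unreadable from compound 1 to compound 2 and a step that the two limits leave unreadable from compound 1 to compound 3 and a step that the two limits leave unreadable from compound 2 to compound 3 and none has a readable size. With compound 3 at the limit of > 64 ug/mL in this assay, at which 3 of the 3 values shown sit, as the only anchor, no direction can be given. The estimated step is a number no higher from compound 3 to compound 4 (the limit leaves the size open) and none beyond the scatter is expected in this assay for now. Compound 4 is expected at 64 ug/mL with an estimated range from 30 ug/mL to 128 ug/mL and quite possibly as a limit again.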

Compound 4, half-maximal inhibitory concentration: 44.3 ug/mL
Compound 4: middle estimate off by 1.4-fold (0.16 log units), on the high side; measured number inside the range.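

In this assay, going by these compounds alone, compound 4 gives the only number, so benzamido on this saturated ring carbon brings the reading inside the assay's range: the limit of > 64 ug/mL in this assay, at which 3 of the 4 values shown sit. The change gives an at least 1.4-fold lower number from compound 3 to compound 4 (0.15 log units; that floor lies within the scatter), an at least 1.4-fold lower number from compound 2 to compound 4 (0.15 log units; that floor lies within the scatter) and an at least 1.4-fold lower number from compound 1 to compound 4 (0.15 log units; that floor lies within the scatter), and each of these is only a floor. The steps among compound 1, compound 2 and compound 3 cannot be read.

Benzamido differs from (cyclobutylcarbonyl)oxy in both its link and its ring, and which of the two goes with the number stays open. A benzoyloxy group on the same ring carbon would separate them.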